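Replacing 4-nitrophenyl with pyridin-4-yl on a carbonyl carbon

The compounds below may be only part of what the source reports. "The series", "measured", "known", "first", "only" and "open" are said of these compounds alone.

Values in a functional assay on MCF7 cells (Homo sapiens) for antiproliferative activity, with a stated time of 5 days (on this read-out lower numbers stand for stronger inhibition and higher numbers for weaker inhibition), for three compounds
- compound 1 `CCCCc1ccc2[nH]c(-c3ccc(C(F)(F)F)cc3)c(C=O)c2c1` gives 66 nM
- compound 2 `CCCCc1ccc2[nH]c(-c3ccc(C(F)(F)F)cc3)c(/C=N/NC(=O)c3ccccc3)c2c1` gives 460 nM
- compound 3 `CCCCc1ccc2[nH]c(-c3ccc(C(F)(F)F)cc3)c(/C=N/NC(=O)c3ccc([N+](=O)[O-])cc3)c2c1` gives 6340 nM

Compound 3 has the highest number of the three, and its steps to both others lie beyond the scatter, so it is the weakest inhibitor here. Compound 4 `CCCCc1ccc2[nH]c(-c3ccc(C(F)(F)F)cc3)c(/C=N/NC(=O)c3ccncc3)c2c1` has pyridin-4-yl in place of 4-nitrophenyl on a carbonyl carbon. The most relevant measured change is a 14-fold higher number from compound 2 to compound 3 (1.14 log units; beyond the scatter) when nitro replaced hydrogen, and that step was large. Compound 4 has no nitro group, which points towards the lower number of compound 2. The step of a 7.0-fold higher number from compound 1 to compound 2 (0.84 log units; beyond the scatter) was modest, and compound 4 keeps most of the group added there, so a number near that of compound 1 is not expected. For the measured compounds named here, no measured compound carries pyridin-4-yl, which leaves the estimate uncertain. A clear step to a lower number in this assay is expected, beyond the scatter and estimated as a 7.0-fold lower number from compound 3 to compound 4 (0.85 log units; beyond the scatter) in size. Compound 4 is estimated at 900 nM with 250 nM to 3500 nM as the expected range.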

Compound 4, half-maximal inhibitory concentration: 100 nM
Compound 4: the middle estimate sits 9.0-fold (0.95 log units) above what was measured, and the stated range ends above it.
By their numbers in this assay, from the lowest: compounds 1 and 4 (each within the scatter of the next); then compound 2; then compound 3.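

In this assay the ring on the carbonyl carbon proves highly sensitive: the step of a 63-fold lower number from compound 3 to compound 4 (1.80 log units; beyond the scatter) shows how much is regained on leaving 4-nitrophenyl for pyridin-4-yl. The earlier compounds shown here showed only a loss on adding nitro to phenyl, whereas the step of a 4.6-fold lower number from compound 2 to compound 4 (0.66 log units; beyond the scatter) shows that a ring nitrogen in place of a ring carbon can move the number the other way. The large added group therefore need not carry a cost, since the step of a 1.5-fold higher number from compound 1 to compound 4 (0.18 log units; within the scatter) stays within the scatter while the phenyl version gave a 7.0-fold higher number from compound 1 to compound 2 (0.84 log units; beyond the scatter) and lay beyond it. No measurement shown explains these shifts.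

On these data alone, whether the ring nitrogen must sit where it does in pyridin-4-yl remains open, as pyridin-3-yl and pyridin-2-yl are absent here. So does how a 4-aminophenyl or 4-methoxyphenyl ring would compare with phenyl.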